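The source may report more compounds than this note shows. Statements on the series, on what has been measured and on what is new or still open speak of the compounds shown alone.

Measured so far:
compound 1 `Cc1cc(S(=O)(=O)/N=C(\N)N/N=C/C#Cc2ccccc2)c(SCc2ccccc2C)cc1Cl`, in a functional assay on HeLa cells (Homo sapiens) for antiproliferative activity, read by MTT assay, with a stated time of 72 h (on this read-out lower numbers stand for stronger inhibition and higher numbers for weaker inhibition), giving 19000 nM;
compound 2 `C/C(C#Cc1ccccc1)=N\N/C(N)=N/S(=O)(=O)c1cc(C)c(Cl)cc1SCc1ccccc1C`, in this assay giving 270000 nM;
compound 3 `Cc1cccc(CSc2cc(Cl)c(C)cc2S(=O)(=O)/N=C(\N)N/N=C/C#Cc2ccccc2)c1`, in this assay giving 11000 nM.

Compound 1 and compound 3 share all their atoms, joined differently: 3-methylphenyl in place of 2-methylphenyl on a saturated chain carbon bound to a sulfur. The step between them is a 1.7-fold lower number from compound 1 to compound 3 (0.24 log units; within the scatter), so the two numbers cannot be told apart with confidence. The other change seen is a group of 11 heavy atoms (10 carbon, 1 nitrogen; one six-membered aromatic ring of carbon only) in place of a group of 10 heavy atoms (9 carbon, 1 nitrogen; one six-membered aromatic ring of carbon only), on an amine nitrogen, and here the step is a 14-fold higher number from compound 1 to compound 2 (1.15 log units; beyond the scatter), a clear weakening of the cell-growth inhibition.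

Compound 4 `C/C(C#Cc1ccccc1)=N\N/C(N)=N/S(=O)(=O)c1cc(C)c(Cl)cc1SCc1cccc(C)c1` is not yet measured. It carries exactly that change on the core of compound 3: a group of 11 heavy atoms (10 carbon, 1 nitrogen; one six-membered aromatic ring of carbon only) in place of a group of 10 heavy atoms (9 carbon, 1 nitrogen; one six-membered aromatic ring of carbon only), on an amine nitrogen. The two cores differ by 3-methylphenyl in place of 2-methylphenyl on a saturated chain carbon bound to a sulfur. The surroundings of the change are the same word for word in both pairs, so this is the same change, not merely the same kind.

Within the data shown here, the expectation for compound 4 is therefore a step of about a 14-fold higher number from compound 3 to compound 4 (1.13 log units; beyond the scatter), resting on the one earlier example of this change, a 14-fold higher number from compound 1 to compound 2 (1.15 log units; beyond the scatter), with a single precedent giving only modest confidence. Compound 4 is thus estimated at 150000 nM in this assay, expected to fall between 50000 nM and 450000 nM.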

Compound 4, half-maximal inhibitory concentration: 105000 nM
Estimate against measurement, compound 4: 1.4-fold (0.15 log units) above, within the range that was stated.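

In this assay, putting the group of 11 heavy atoms in place of the group of 10 heavy atoms on the amine nitrogen again gives a clear weakening, a 9.5-fold higher number from compound 3 to compound 4 (0.98 log units; beyond the scatter), and the size of that loss carries over from one core to the other: the same change on two cores in this assay, a 14-fold higher number (1.15 log units; beyond the scatter) from compound 1 to compound 2 and a 9.5-fold higher number (0.98 log units; beyond the scatter) from compound 3 to compound 4, 1.5-fold (0.17 log units) apart, within the scatter of two such steps. Swapping 2-methylphenyl for 3-methylphenyl on the saturated chain carbon bound to a sulfur gives a 2.6-fold lower number from compound 2 to compound 4 (0.41 log units; beyond the scatter), and this step also agrees with its earlier counterpart: the same change on two cores in this assay, a 1.7-fold lower number (0.24 log units; within the scatter) from compound 1 to compound 3 and a 2.6-fold lower number (0.41 log units; beyond the scatter) from compound 2 to compound 4, 1.5-fold (0.17 log units) apart, within the scatter of two such steps. Among these compounds, this shows that the two changes behaved consistently across these four compounds, but it rests on only two cores that differ solely in where one methyl sits, so it does not show that the loss would carry over to a more different core or explain why it occurs.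

From the compounds shown here alone, it remains open whether an ethyl group in the same place would weaken the inhibition further. Going by these compounds, it is also open whether a 4-methylphenyl or plain phenyl group on that chain carbon would fit the same pattern.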